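Swapping the Sulfonyl Aryl Group in Compound 1

The compounds below may be only part of what the source reports. "The series", "measured", "known", "first", "only" and "open" are said of these compounds alone.

For the measured compounds named here, compound 1 `CC1CCN(c2c(S(=O)(=O)c3ccc(F)c(Cl)c3)cnc3cc(Cl)ccc23)CC1` is one of three compounds measured in an assay on isolated protein for displacement of a labelled ligand from metabotropic glutamate receptor 5 (Homo sapiens), with a stated time of 60 min, tested at 1 uM; on this read-out higher numbers stand for more inhibition at the one concentration tested (going by the name of the read-out) and lower numbers for less inhibition. In this assay compound 1 gives 94%. Compound 2 `CC1CCN(c2c(S(=O)(=O)c3ccc(F)c(Cl)c3)cnc3cc(F)ccc23)CC1` gives 94%, and the step of no change at the digits printed from compound 1 to compound 2 (within the scatter) shows no change within the scatter, so the two stand level, together at the top of the three numbers. Compound 3 `CCN1CCN(c2c(S(=O)(=O)c3ccccc3)cnc3ccccc23)CC1` gives 1.7%, far below compound 1; it differs from compound 1 in several places at once, so only its value can be read, not any single change.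

Compound 4 `COc1ccc(S(=O)(=O)c2cnc3cc(Cl)ccc3c2N2CCC(C)CC2)cc1` is the compound still to be measured. It differs from compound 1 in one place: 4-methoxyphenyl in place of 3-chloro-4-fluorophenyl on a sulfonyl sulfur. Going by the values given here, no measured step touches the group on the sulfonyl sulfur; the only step known, from compound 1 to compound 2, alters the chloro on the core ring and is flat. The expectation for compound 4 therefore rests on little, and a moderate drop in this assay is estimated, a number 16 percentage points lower from compound 1 to compound 4 (beyond the scatter). Compound 4 is expected to give 78%, between 40% and 97%.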

Compound 4, a percentage reported as inhibition, at one concentration (the size of the read-out at that concentration, not a potency): 79%
For compound 4 the middle estimate is 1 percentage points below the measured one; measured number inside the range.
By their numbers in this assay, from the lowest: compound 3; then compound 4; then compounds 1 and 2 (each within the scatter of the next).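

In this assay, for the compounds shown here, the first reading on the group at the sulfonyl sulfur is a number 15 percentage points lower from compound 1 to compound 4 (beyond the scatter) when 4-methoxyphenyl replaces 3-chloro-4-fluorophenyl on the shared core. Going by these compounds alone, the 3-chloro-4-fluorophenyl group is therefore not the only group here that keeps a high reading: with a different aryl group of the same heavy-atom count, compound 4 still gives 79% at the one concentration tested. No measurement at hand explains the modest step.

This single swap removes the chloro and fluoro groups and adds the methoxy group all at once, so the share of each change in the step cannot be separated. A 4-fluorophenyl or 3-chlorophenyl group would help to pull these changes apart, while a cyclohexyl group would test whether this position needs an aromatic ring at all.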